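A few compounds are considered here, and "the series" means these few. Any claim that something is new, unique, unknown or untested is made for them only; others in the source may bear on it.

Of the compounds shown here, three have so far been measured in a physicochemical assay for solubility, measured as kinetic solubility; a lower number here means a less soluble compound, a higher number a more soluble compound. Compound 1, `CC(=O)Nc1cc(-c2ccc(N(C)C(=O)c3c(F)cccc3Cl)c(N3CC4CC4C3)c2)n(C2CCC2)n1`, gives 0.5 ug/mL and stands lowest of the three. Compound 3, `CC(=O)Nc1cc(-c2ccc(N(C)C(=O)c3c(C)cccc3F)c(N3CC4CC4C3)c2)n(C(C)C)n1`, gives 17 ug/mL, and compound 2, `CC(=O)Nc1cc(-c2cnc(N(C)C(=O)c3c(F)cccc3Cl)c(N3CCCCC3)c2)n(C(C)C)n1`, gives 37.4 ug/mL; the gap from compound 1 to each of these lies beyond the usual scatter of the measurement. Compound 4, `CC(=O)Nc1cc(-c2ccc(N(C)C(=O)c3c(F)cccc3Cl)c(N3CC4CC4C3)c2)n(CC2CC2)n1`, has not yet been measured. It differs from compound 1 in one place: cyclopropylmethyl in place of cyclobutyl on an aromatic nitrogen, the two compounds holding the same atoms joined differently. Among the measured compounds shown here, no measured pair differs in just this way, so there is no measured step of this kind to lean on. Compound 4 is expected to stay close to compound 1, with a 2.0-fold higher number from compound 1 to compound 4 (0.30 log units; within the scatter) estimated to lie within the scatter or only slightly beyond it, in the upward direction if anywhere. For compound 4 the estimate in this assay is 1 ug/mL, with a range from 0.3 ug/mL to 3.5 ug/mL.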

Compound 4, solubility: 10.1 ug/mL
Beside the measured number, compound 4's estimate is 10-fold (1.00 log units) below it; the measured number lies above the stated range.
By their numbers in this assay, from the lowest: compound 1; then compounds 4 and 3 (each within the scatter of the next); then compound 2.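

In this assay the change from cyclobutyl to cyclopropylmethyl on an aromatic nitrogen gives a 20-fold higher number from compound 1 to compound 4 (1.31 log units; beyond the scatter) and counts as a large step, although the two compounds hold the same atoms joined differently. Among the compounds shown here, this position is therefore sensitive in this assay, something the earlier compounds could not show, as they differed from one another in more than one place. Nothing measured here explains the size of this step.

As far as these compounds go, it remains open whether the same change would give a similar step if other parts of the core of compound 1 were altered. From the compounds shown here alone, it is also open how this nitrogen would respond to a group of a different kind, such as a longer carbon chain, or a chain ending in an amine or a hydroxyl group.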